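The compounds below may be only part of what the source reports. "The series", "measured", "known", "first", "only" and "open" are said of these compounds alone.

Three compounds share one core and are set apart only by the aryl group on the sulfonamide nitrogen. Compound 1 `CCOc1ccc(Cc2nnc(CN(c3ccccc3CC)S(=O)(=O)c3ccc(C)cc3)o2)cc1` gives 39.8 nM in a functional assay on CHO cells for antagonist activity at prostaglandin E2 receptor EP1 subtype (Homo sapiens), read by FLIPR and calcium flux; on this read-out higher numbers stand for weaker inhibition and lower numbers for stronger inhibition. Compound 2 `CCOc1ccc(Cc2nnc(CN(c3cccc(Cl)c3C)S(=O)(=O)c3ccc(C)cc3)o2)cc1` gives 50.1 nM in this assay, and compound 3 `CCOc1ccc(Cc2nnc(CN(c3cccc(Cl)c3Cl)S(=O)(=O)c3ccc(C)cc3)o2)cc1` gives 31.6 nM in this assay. Compound 3 carries the smallest of the three numbers, but a 1.3-fold lower number from compound 1 to compound 3 (0.10 log units; within the scatter) and a 1.6-fold lower number from compound 2 to compound 3 (0.20 log units; within the scatter) both fall within the scatter, as does a 1.3-fold higher number from compound 1 to compound 2 (0.10 log units; within the scatter); the three compounds cannot be told apart on these data.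

Compound 4 `CCOc1ccc(Cc2nnc(CN(c3cccc(Cl)c3Cl)S(=O)(=O)c3ccc(C(F)(F)F)cc3)o2)cc1` departs from compound 3 elsewhere in the molecule: trifluoromethyl in place of methyl on an aromatic carbon. Within the data shown here, none of the measured steps touches this position; all three concern the aryl group on the sulfonamide nitrogen, and each of them stayed within the scatter. Among the measured compounds shown here, there is thus no measured step that bears on the change to compound 4, and nothing in the three numbers points to a direction. The expected step in this assay is a 1.0-fold higher number from compound 3 to compound 4 (0.01 log units; within the scatter), that is, none beyond the scatter. Compound 4 is therefore estimated to give 32 nM in this assay. For compound 4 the expected range runs from 12 nM to 85 nM.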

Compound 4, inhibition constant: 6.31 nM
Compound 4: the middle estimate sits 5.1-fold (0.71 log units) above what was measured; measured number outside the range, below it.
By their numbers in this assay, from the lowest: compound 4; then compounds 3, 1 and 2 (each within the scatter of the next).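

In this assay trifluoromethyl in place of methyl gives a 5.0-fold lower number from compound 3 to compound 4 (0.70 log units; beyond the scatter) and so becomes the first step among these compounds to pass beyond the scatter. Among these compounds, the earlier steps all changed the aryl group on the sulfonamide nitrogen and none of them separated the compounds, so this position, on the ring para to a large group, is the first place where a single change moves the number by a clear margin, though the step is still a modest one. The data hold nothing that says why exchanging methyl for trifluoromethyl lowers the number at this position.

Going by these compounds, this finding rests on a single pair with the 2,3-dichlorophenyl group on the sulfonamide nitrogen, so it remains open whether the same exchange would lower the number with 2-ethylphenyl or 3-chloro-2-methylphenyl on that nitrogen. On these data alone, it also remains open what a chloro, a methoxy, a nitrile or a carboxylic acid would give in this same place, and so whether the lower number is particular to trifluoromethyl or is shared by other groups.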